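The source may report more compounds than this note shows. Statements on the series, on what has been measured and on what is new or still open speak of the compounds shown alone.

For the measured compounds named here, in an ADME assay on Vero cells (Chlorocebus sabaeus) for cytotoxicity, read by MTT assay, with a stated time of 48 h (on this read-out higher numbers stand for lower toxicity in this test and lower numbers for higher toxicity in this test), compound 3 `CC(C)(NC(=O)c1ccc([N+](=O)[O-])o1)c1ccc(COc2ccc(Cl)cc2)cc1` gives 120000 nM, the only number among the three values shown. Compound 1 `CC(C)(C)c1ccc(C(C)(C)NC(=O)c2ccc([N+](=O)[O-])o2)cc1` gives only a limit of > 150000 nM in this assay. Compound 2 `CC(C)(NC(=O)c1ccc([N+](=O)[O-])o1)c1ccc(-c2ccc(Cl)cc2)cc1` likewise gives only a limit of > 140000 nM in this assay. Of the measured steps, an at least 1.2-fold lower number from compound 1 to compound 3 (0.09 log units; that floor lies within the scatter) and an at least 1.1-fold lower number from compound 2 to compound 3 (0.06 log units; that floor lies within the scatter) both have floors within the scatter, while a step that the two limits leave unreadable from compound 1 to compound 2. Compound 4 `CC(C)(NC(=O)c1ccc([N+](=O)[O-])o1)c1ccc(COc2ccc(C(F)(F)F)cc2)cc1` differs from compound 3 by trifluoromethyl in place of chloro on an aromatic carbon. Going by the values given here, none of the measured steps touches this change, and the two readable ones stay within the scatter, so no step beyond the scatter is expected in this assay. Compound 4 is therefore estimated at 120000 nM, between 60000 nM and 240000 nM, which is expected to mean no change at the digits printed from compound 3 to compound 4 (within the scatter).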

Compound 4, half-maximal cytotoxic concentration: 7000 nM
Compound 4: middle estimate off by 17-fold (1.23 log units), on the high side; measured number outside the range, below it.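

In this assay, trifluoromethyl in place of chloro on the aromatic carbon para to a large group gives a 17-fold lower number from compound 3 to compound 4 (1.23 log units; beyond the scatter), the only step shown that is read as beyond the scatter. This place on the ring is therefore not indifferent in this test: one change there, with the rest of the molecule held the same, shifts the read-out towards higher toxicity, whereas the earlier readable floors stayed within the scatter. Going by these compounds, whether a nitrile, an amine or a carboxylic acid at the same place would stay close to chloro or to trifluoromethyl remains open. Nothing shown here gives a measured reason for this step.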